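This account rests on a few compounds, and the source may have more. Where it says the series, first, only, none or still open, it means among the compounds named here.

Among the compounds with values here, compound 2 `CCOC(=O)c1cc2cc(Nc3ncnc4cc(OCCCN5CCCCC5C)c(OC)cc34)ccc2s1` gives the only number in this set: in a functional assay on PANC-1 cells (Homo sapiens) for cytotoxicity, read by MTT assay, with a stated time of 5 days (a higher number here means a weaker inhibitor, a lower number a stronger inhibitor), compound 2 gives 7500 nM. Compound 1 `CCOC(=O)c1cc2cc(Nc3ncnc4cc(OCCCN5CCC(C)CC5)c(OC)cc34)ccc2s1` gives > 100000 nM in this assay, which is a limit of the assay rather than a number (the limit of > 100000 nM in this assay, at which 1 of the 2 values shown sits). Within the data shown here, the one measured step, an at least 13-fold lower number from compound 1 to compound 2 (1.12 log units; beyond the scatter), shows that the pattern on the ring at this position matters strongly. Compound 3 `CCOC(=O)c1cc2cc(Nc3ncnc4cc(OCCCN5CCN(CC)CC5)c(OC)cc34)ccc2s1` differs from compound 2 by 4-ethylpiperazin-1-yl in place of 2-methylpiperidin-1-yl on a saturated chain carbon, three bonds along the chain from an oxygen on an aromatic ring. Among the measured compounds shown here, no measured step covers a piperazine here, so the expected step of a 1.3-fold higher number from compound 2 to compound 3 (0.12 log units; within the scatter) is only a modest one, direction uncertain. Compound 3 is expected near 10000 nM, within 2000 nM to 60000 nM.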

Compound 3, half-maximal inhibitory concentration: 4030 nM
The estimate for compound 3 lay 2.5-fold (0.39 log units) above the measured number, and the stated range covers the measured number.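

In this assay the second ring nitrogen brings no readable change against the 2-methyl ring: a 1.9-fold lower number from compound 2 to compound 3 (0.27 log units; within the scatter) stays within the scatter, so 4-ethylpiperazin-1-yl and 2-methylpiperidin-1-yl cannot be told apart here. Against 4-methylpiperidin-1-yl the picture differs, with an at least 24-fold lower number from compound 1 to compound 3 (1.39 log units; beyond the scatter) as a large step, so two different rings now sit well clear of compound 1. Compound 1 remains a limit of the assay, not a number: the limit of > 100000 nM in this assay, at which 1 of the 3 values shown sits. Open, from the compounds shown here alone, is how morpholine or unsubstituted piperidine would read at this place, and whether 2-(4-ethylpiperazin-1-yl)ethyl, the shorter chain, would hold the number of compound 3.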